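Pyrimidin-2-yl for 3-fluorophenyl on a carbonyl carbon

The source may report more compounds than this note shows. Statements on the series, on what has been measured and on what is new or still open speak of the compounds shown alone.

Measured so far in a functional assay on COR-L23 cells (Homo sapiens) for antiproliferative activity, read by CellTiter-Glo, with a stated time of 72 h; on this read-out lower numbers stand for stronger inhibition and higher numbers for weaker inhibition:
Compound 1 `O=C(Nc1ccc(CN2Cc3ccccc3C2=O)cc1)N1CCC(c2cccnc2)CC1` gives 1150 nM
Compound 2 `C[C@@H](c1ccc(NC(=O)N2CC(c3cccnc3)C2)cc1)N1Cc2ccccc2C1=O` gives 8 nM
Compound 3 `C[C@H](NC(=O)c1cccc(F)c1)c1ccc(NC(=O)N2CC(c3cccnc3)C2)cc1` gives 10 nM

Compound 3 sits level with compound 2 and far under compound 1 on these numbers. The next compound to be tested is compound 4 `C[C@H](NC(=O)c1ncccn1)c1ccc(NC(=O)N2CC(c3cccnc3)C2)cc1`, which carries pyrimidin-2-yl in place of 3-fluorophenyl on a carbonyl carbon.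

Going by the values given here, no measured step touches this carbonyl carbon directly. The nearest evidence is a 1.3-fold higher number from compound 2 to compound 3 (0.10 log units; within the scatter), which exchanged a whole group on a saturated chain carbon and stayed within the scatter. Among the compounds with values here, that is a single pair at a neighbouring part of the structure, and no measured compound has pyrimidin-2-yl at all. Compound 1 shows that high numbers do occur in this small set, although it differs from the others in more than one place. A modest step in this assay is therefore expected, most likely within the scatter and leaning towards a higher number, with real uncertainty in both directions.

The expected change is a 1.6-fold higher number from compound 3 to compound 4 (0.20 log units; within the scatter) in size. For compound 4 the estimated value is 16 nM, with an expected range from 5 nM to 50 nM.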

Compound 4, half-maximal inhibitory concentration: 130 nM
The estimate for compound 4 lay 8.1-fold (0.91 log units) below the measured number; measured number outside the range, above it.
By their numbers in this assay, from the lowest: compounds 2 and 3 (each within the scatter of the next); then compound 4; then compound 1.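

In this assay, going by these compounds alone, the group on the carbonyl carbon turns out to matter: pyrimidin-2-yl in place of 3-fluorophenyl gives a 13-fold higher number from compound 3 to compound 4 (1.11 log units; beyond the scatter) and is the first large step confined to this one place. Within the data shown here, the group on the saturated chain carbon had looked interchangeable on the single earlier step of a 1.3-fold higher number from compound 2 to compound 3 (0.10 log units; within the scatter) but now shows otherwise with a 16-fold higher number from compound 2 to compound 4 (1.21 log units; beyond the scatter) so that the earlier match held for the ((3-fluorophenyl)carbonyl)amino group and does not extend to the ((pyrimidin-2-yl)carbonyl)amino group. Nothing measured here bears on what lies behind the size of this step.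

The two ring nitrogens enter and the fluorine leaves in one exchange, and the compounds shown do not separate these two changes. A plain phenyl or a pyridin-2-yl on the same carbonyl carbon would pull them apart, and whether any other ring with nitrogen in it can match 3-fluorophenyl at this place remains an open question.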